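The source may hold more compounds than are shown below. What is called first, only, known or untested is meant among the compounds shown, and "the series" means these compounds.

Working notes on the series. Within the data shown here, the two measured members, compound 1 `C[C@@H]1CN(c2cccc3c2C[C@H](CN(C)[C@H]2CCCc4cccnc42)NC3)C[C@H](C)N1` and compound 2 `CN1CCN(c2cccc3c2C[C@H](CN(C)[C@H]2CCCc4cccnc42)N(C)C3)CC1`, share the same core. In a functional assay on CCRF-CEM cells for agonist activity at C-X-C chemokine receptor type 4 (Homo sapiens), read by calcium flux, with a stated time of 25 min (a higher number here means that more compound is needed for the effect, a lower number that less compound is needed), compound 1 returns only a limit of the assay, > 30000 nM. Compound 2 likewise gives only a limit in this assay, > 30000 nM. Both values sit at the limit of > 30000 nM in this assay, at which 2 of the 2 values shown sit, so compound 1 has no numerical position within the set and neither value can be ordered against the other. The next member, compound 3 `CN(C[C@H]1Cc2c(cccc2N2CCNC(C)(C)C2)CN1)[C@H]1CCCc2cccnc21`, differs from compound 1 by 3,3-dimethylpiperazin-1-yl in place of 3,5-dimethylpiperazin-1-yl on an aromatic carbon. Among the measured compounds shown here, no measured pair differs in a single place, so no calibrated step exists for this change. In this assay the expected step is a number no higher from compound 1 to compound 3 (the limit leaves the size open), which amounts to nothing beyond the scatter, with a limit the most likely outcome. Compound 3 is therefore estimated at 30000 nM, with a range from 10000 nM to 100000 nM.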

Compound 3, half-maximal effective concentration: > 30000 nM
Compound 3 was reported as a limit; the forecaster's own chance of this, stated with the estimate: 80%; the middle value sits exactly at the limit.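

In this assay compound 3 gives > 30000 nM as a limit of the assay. Among these compounds, compound 1 also stands at a limit, so no step from compound 1 to compound 3 can be read. The compounds shown leave open whether 3,3-dimethylpiperazin-1-yl and 3,5-dimethylpiperazin-1-yl differ at all on the shared core.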